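Losing the 4-aminobutyl chain from a long-lived compound

This account rests on a few compounds, and the source may have more. Where it says the series, first, only, none or still open, it means among the compounds named here.

Measured so far in an ADME assay (liver) for metabolic stability, with Liver microsome (Homo sapiens) as the target, read by LC-MS, using microsomes (on this read-out higher numbers stand for a longer-lived compound and lower numbers for a shorter-lived compound), are two compounds.

compound 1 `CS(=O)(=O)c1ccc(-c2cnc(N)c(-c3ccc(C(F)(F)F)cc3)n2)cc1` gives 2.58 h
compound 2 `COc1ccc(-c2cc(-c3ccc(S(C)(=O)=O)cc3)cnc2NCCCCN)cn1` gives > 4.16 h

Compound 2 gives > 4.16 h as its reading, and that reading is a limit of the assay, not a number. Compound 3 `COc1ccc(-c2cc(-c3ccc(S(C)(=O)=O)cc3)cnc2N)cn1` has not been measured yet. It differs from compound 2 in one place. The change is hydrogen in place of 4-aminobutyl on a nitrogen on an aromatic ring and in words it puts hydrogen in place of 4-aminobutyl on a nitrogen on an aromatic ring. Going by the values given here, no measured pair shows this change on its own. Among the compounds with values here, the only guide is compound 1, which carries the plain amino group on a different core and gives 2.58 h as a true number, so a somewhat shorter half-life is expected for compound 3. The expected step is an at least 1.3-fold lower number from compound 2 to compound 3 (0.14 log units; that floor lies within the scatter) and it may stay close to the scatter. For compound 3 the estimated half-life is 3 h with an expected range of 1.3 h to 7 h in this assay once it is measured.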

Compound 3, half-life in the Liver microsome assay: 4.68 h
The estimate for compound 3 lay 1.6-fold (0.19 log units) below the measured number; measured number inside the range.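

In the Liver microsome assay compound 2 gives > 4.16 h as its reading, and that reading is a limit of the assay, not a number. The step from compound 2 to compound 3 cannot be read. The compounds shown leave open the true half-life of compound 2, and whether removing the 4-aminobutyl chain changes it. In a physicochemical assay for lipophilicity, read by HPLC, at pH 7.4 (a higher number here means a more lipophilic compound, a lower number a more polar compound), compound 2 gives 1.8 and compound 3 gives 2.2.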